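The source may hold more compounds than are shown below. What is called first, only, known or untested is meant among the compounds shown, and "the series" means these compounds.

The shared core appears first in compound 1 `Nc1nc(-c2ccc(Cl)cc2)cn1/N=C/c1cc2ccccc2nc1Cl`. In a functional assay on HCT-116 cells (Homo sapiens) for cytotoxicity, read by MTT assay, with a stated time of 48 h (a higher number here means a weaker inhibitor, a lower number a stronger inhibitor), compound 1 reaches only the limit > 50000 nM, a limit rather than a number. Compound 2 `Cc1ccc2nc(Cl)c(/C=N/n3cc(-c4ccc(Cl)cc4)nc3N)cc2c1` carries a methyl in place of hydrogen on an aromatic carbon. In this assay compound 2 likewise stops at the limit > 50000 nM. The step that the two limits leave unreadable from compound 1 to compound 2 is therefore not readable, because of the limit of > 50000 nM in this assay, at which 2 of the 2 values shown sit. Compound 3 `Cc1ccc2nc(Cl)c(/C=N/n3cc(-c4ccc5ccccc5c4)nc3N)cc2c1` differs from compound 2 by naphthalen-2-yl in place of 4-chlorophenyl on an aromatic carbon. Within the data shown here, no measured step touches this change; the only one recorded, a step that the two limits leave unreadable from compound 1 to compound 2, gives no size, so no direction in this assay can be drawn from it. Compound 2 offers only a limit. Compound 3 is expected to stay near that limit, with the step that the limit leaves unreadable from compound 2 to compound 3 meaning no readable change. The estimate for compound 3 in this assay is 60000 nM, between 15000 nM and 250000 nM.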

Compound 3, half-maximal inhibitory concentration: 27400 nM
For compound 3 the middle estimate is 2.2-fold (0.34 log units) above the measured one; the range from low to high includes it.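

In this assay, compound 3 is the only one of the three compounds shown to give a number rather than a limit, so the aromatic carbon of the five-membered ring is the one place shown where a change brings a readable value. Naphthalen-2-yl in place of 4-chlorophenyl there gives an at least 1.8-fold lower number from compound 2 to compound 3 (0.26 log units; that floor lies within the scatter). Only a floor can be read for this step, and it cannot be called larger than the scatter, because compound 2 rests on a limit: the limit of > 50000 nM in this assay, at which 2 of the 3 values shown sit.

The compounds shown leave open whether the lower number goes with the second aromatic ring or with the loss of chlorine. They also leave open what an unsubstituted phenyl, a morpholine or a carboxylic acid would give on this aromatic carbon.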